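Taking One Methoxy Group Off Compound 2

This account rests on a few compounds, and the source may have more. Where it says the series, first, only, none or still open, it means among the compounds named here.

Within the data shown here, in a functional assay on MDA-MB-231 cells (Homo sapiens) for antiproliferative activity, read by MTT assay, with a stated time of 48 h (on this read-out higher numbers stand for weaker inhibition of growth and lower numbers for stronger inhibition of growth), compound 1 `COC(=O)N1N=C(c2ccc(OC)cc2)CC1c1cc(OC)c(OC)c(OC)c1` gives 1990 nM and holds the lower of the two numbers measured so far. Compound 2 `COC(=O)N1N=C(c2cc(OC)c(OC)c(OC)c2)CC1c1cc(OC)c(OC)c(OC)c1` gives 11100 nM and stands highest of the two, which means weaker inhibition of growth, and its gap to compound 1 lies beyond the usual scatter.

Compound 3 `COC(=O)N1N=C(c2ccc(OC)c(OC)c2)CC1c1cc(OC)c(OC)c(OC)c1` has not been measured yet. It differs from compound 2 by hydrogen in place of methoxy on an aromatic carbon, and that carbon is ortho to a methoxy group. Among the measured compounds shown here, no measured pair differs in one place only, so there is no direct step to lean on. For the measured compounds named here, the only guide is compound 1 at 1990 nM with fewer methoxy groups on that ring than compound 2, which points to a lower number. The expected change is a 2.5-fold lower number from compound 2 to compound 3 (0.39 log units; beyond the scatter) in this assay and would be a modest one, toward stronger inhibition, probably just beyond the scatter. For compound 3 the estimated value is 4500 nM (expected range 1600 nM to 12000 nM).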

Compound 3, concentration for 50% growth inhibition: 9900 nM
The estimate for compound 3 lay 2.2-fold (0.34 log units) below the measured number; low and high end bracket the measured number.
By their numbers in this assay, from the lowest: compound 1; then compounds 3 and 2 (each within the scatter of the next).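

In this assay, replacing the methoxy group ortho to a methoxy group with hydrogen gives a 1.1-fold lower number from compound 2 to compound 3 (0.05 log units; within the scatter), so compound 2 and compound 3 cannot be told apart and this methoxy group shows no readable contribution to growth inhibition in these cells. Among these compounds, the change on the same ring that does register is methoxy in place of hydrogen on an aromatic carbon, which gives a 5.0-fold higher number from compound 1 to compound 3 (0.70 log units; beyond the scatter): the first extra methoxy group on the ring of compound 1 brings a step beyond the scatter, while a further one, leading on to compound 2, brings none that can be read. Nothing available explains why these two steps differ in size.

The compounds shown leave open whether this carbon tolerates only hydrogen and methoxy equally or whether another group there, such as a hydroxyl, a chlorine atom or an amine, would move the number away from that of compound 3. They also leave open whether the same two steps would hold on any cell line other than this one.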